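A few compounds are considered here, and "the series" means these few. Any claim that something is new, unique, unknown or untested is made for them only; others in the source may bear on it.

Compound 1 `CC1(C)[C@H]2CC[C@]1(C)N(Cc1cn(-c3cccc(Cl)c3)nn1)C(=O)C2` carries a bicyclic amide core linked through a methylene to a triazole that bears a 3-chlorophenyl group. In a functional assay on PANC-1 cells (Homo sapiens) for inhibition, read by MTT assay, with a stated time of 24 h (on this read-out higher numbers stand for weaker inhibition and lower numbers for stronger inhibition), compound 1 gives 260 nM, and neither of the other two measured compounds sits beyond the scatter from it. Compound 2 `CC1(C)[C@H]2CC[C@]1(C)N(Cc1cn(-c3ccc(Br)cc3)nn1)C(=O)C2` gives 200 nM in this assay, and compound 3 `Cc1ccccc1-n1cc(CN2C(=O)C[C@@H]3CC[C@@]2(C)C3(C)C)nn1` gives 250 nM. The steps were a 1.3-fold lower number from compound 1 to compound 2 (0.11 log units; within the scatter) and a 1.0-fold lower number from compound 1 to compound 3 (0.02 log units; within the scatter), so swapping the aryl group on the triazole nitrogen has so far left the number essentially unchanged. Compound 4 `CC1(C)[C@H]2CC[C@]1(C)N(Cc1cn(-c3ccc(Cl)cc3)nn1)C(=O)C2` differs from compound 1 in one place: 4-chlorophenyl in place of 3-chlorophenyl on an aromatic nitrogen. Since every comparable swap stayed within the scatter, no step beyond the scatter is expected here. Compound 4 is therefore estimated to give 230 nM, within a range from 110 nM to 500 nM, a step of a 1.1-fold lower number from compound 1 to compound 4 (0.05 log units; within the scatter) that is expected to be within the scatter.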

Compound 4, half-maximal inhibitory concentration: 440 nM
Compound 4: the middle estimate sits 1.9-fold (0.28 log units) below what was measured, within the range that was stated.
By their numbers in this assay, from the lowest: compounds 2, 3, 1 and 4 (each within the scatter of the next, the first and the last beyond it).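

Moving the chlorine to give the 4-chlorophenyl group produces a step within the scatter (a 1.7-fold higher number from compound 1 to compound 4 (0.23 log units; within the scatter)), and replacing 2-methylphenyl with it does likewise (a 1.8-fold higher number from compound 3 to compound 4 (0.25 log units; within the scatter)) in this assay. Chloro in place of bromo gives the first step beyond the scatter in this set, though a modest one (a 2.2-fold higher number from compound 2 to compound 4 (0.34 log units; beyond the scatter)), so the halogen on this aryl group can shift the number. Nothing available explains that step. Still open, as far as these compounds go, is whether a phenyl group carrying an amine or a carboxylic acid in place of the halogen would shift the number further.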